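The source may hold more compounds than are shown below. What is called first, only, known or untested is meant among the compounds shown, and "the series" means these compounds.

Working notes on the series. In an assay on isolated protein for inhibition of aldehyde dehydrogenase 1A1 (Homo sapiens), read by spectrophotometry, tested at 10 uM (a lower number here means less inhibition, a higher number more inhibition at the concentration tested (going by the name of the read-out)), compound 1 `O=C(C1CC1)N1CCN(Cc2nc3ccccc3n2Cc2ccccc2C(F)(F)F)CC1` gives 56.3%. Compound 2 `Cc1cccc(Cn2c(CN3CCN(C(=O)C4CCCCC4)CC3)nc3ccccc32)c1` gives 31.9% in this assay, and compound 3 `CC(C)CCn1c(OC2CCN(C(=O)c3ccco3)CC2)nc2ccccc21` gives 30.8%. On these three numbers compound 2 stands second; its nearest neighbour is compound 3, whose number lies within the usual scatter of compound 2's, while compound 1 is furthest, with a number beyond the scatter above it. Among the measured compounds shown here, no step between two measured compounds that differ in one place is available, so no measured effect of any single change can be drawn from the three.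

Compound 4 `Cc1cccc(Cn2c(CN3CCN(C(=O)c4ccc(Br)cc4)CC3)nc3ccccc32)c1` has not yet been measured in this assay. It differs from compound 2 in one place: 4-bromophenyl in place of cyclohexyl on a carbonyl carbon. For the measured compounds named here, no measured pair shows this exchange, so the size of the step is unknown; a step within the scatter is expected in either direction, given that compound 2 at 31.9% and compound 3 at 30.8% carry different carbonyl substituents and yet sit close together. The step of a number 3.1 percentage points higher from compound 2 to compound 4 (within the scatter) is an estimate, not a measurement. Compound 4 is expected to give about 35%, within a range of 15% to 55%, in this assay.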

Compound 4, a percentage reported as inhibition, at one concentration (the size of the read-out at that concentration, not a potency): 25.8%
Compound 4: middle estimate off by 9.2 percentage points, on the high side, and the stated range covers the measured number.
By their numbers in this assay, from the lowest: compounds 4, 3 and 2 (each within the scatter of the next); then compound 1.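

Among the compounds shown here, the step is the only measured single-place exchange: on a carbonyl carbon whose other neighbour is the amide-type nitrogen in a ring, 4-bromophenyl in place of cyclohexyl gives, in this assay, a number 6.1 percentage points lower from compound 2 to compound 4 (within the scatter). This single pair therefore does not separate the two groups at this position, at the concentration tested, even though one is an aromatic ring bearing bromine and the other a non-aromatic ring of carbon only. No data at hand bear on the reason for this result.

On these data alone, it remains open whether a methyl group, a longer alkyl chain or an amine-bearing group on this carbonyl carbon would also stay within the scatter of compound 2. As far as these compounds go, it is equally open whether the same exchange would read alike on the core of compound 1.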